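The compounds below may be only part of what the source reports. "The series", "measured", "known", "first", "only" and "open" are said of these compounds alone.

Compound 1 `COc1cccc(-c2c(C)n(Cc3c(F)cccc3F)c(=O)n([C@@H](C)CNCc3ccccc3F)c2=O)c1` is the starting point. In an assay on HEK293 cells for binding affinity to Gonadotropin-releasing hormone receptor (Homo sapiens) (on this read-out higher numbers stand for weaker inhibition and lower numbers for stronger inhibition), compound 1 gives 550 nM. Compound 2 `COc1cccc(-c2c(C)n(Cc3c(F)cccc3F)c(=O)n([C@H](C)CNCc3ccc(F)cc3)c2=O)c1` differs only in the position of the fluorine on the benzyl group of the amine-bearing side chain, and in this assay compound 2 gives 250 nM. Among the compounds with values here, that shift, a 2.2-fold lower number from compound 1 to compound 2 (0.34 log units; beyond the scatter), is modest but beyond the scatter, so compound 2 stands as the lower of the two numbers known here.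

Compound 3 `COc1cccc(-c2c(C)n(Cc3c(F)cccc3F)c(=O)n(C3CCNC3)c2=O)c1` keeps the whole shared core and changes the same side chain more deeply: pyrrolidin-3-yl in place of 1-(((4-fluorobenzyl)amino)methyl)ethyl on an aromatic nitrogen. Within the data shown here, the only measured step, from compound 1 to compound 2, tells how the fluorine position on the benzyl group matters, not what happens when the benzyl group and the open chain are removed altogether, so it offers little direct guidance; it shows only that this side chain tolerates a small change without a large swing. The replacement here is far larger in scope. He therefore expects a weaker number for compound 3, with wide uncertainty, as a 6.0-fold higher number from compound 2 to compound 3 (0.78 log units; beyond the scatter), and estimates compound 3 at 1500 nM, within a range from 400 nM to 6000 nM.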

Compound 3, inhibition constant: 15000 nM
Beside the measured number, compound 3's estimate is 10-fold (1.00 log units) below it, outside the stated range (above it).
By their numbers in this assay, from the lowest: compound 2; then compound 1; then compound 3.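

The side chain on this aromatic nitrogen proved far less forgiving than the fluorine shift suggested: in this assay, pyrrolidin-3-yl in place of the 4-fluorobenzyl chain gives a 60-fold higher number from compound 2 to compound 3 (1.78 log units; beyond the scatter) and, in place of the 2-fluorobenzyl chain, a 27-fold higher number from compound 1 to compound 3 (1.44 log units; beyond the scatter). Within the data shown here, both steps are large, whereas the only earlier step was modest, so this position responds strongly to a change that removes the six-membered aromatic ring and reduces the group to five heavy atoms, even though the counts of one hydrogen-bond donor and one hydrogen-bond acceptor stay the same. No measurement here gives a reason for the rise, and the result has to stand without an explanation.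

The compounds shown do not separate the loss of the fluorobenzyl group from the closing of the open chain into a ring, since both changes arrive together in compound 3. A 1-(4-fluorobenzyl)pyrrolidin-3-yl group would keep the benzyl group on the ring, while a 1-(aminomethyl)ethyl chain with a free primary amine would keep the open chain without it, and either could help to tell these two changes apart.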